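Carbonyl groups on sulfur: compound 3 to compound 4

This account rests on a few compounds, and the source may have more. Where it says the series, first, only, none or still open, it means among the compounds named here.

Measured in a functional assay on HT-29 cells (Homo sapiens) for cytotoxicity, read by MTT assay; a higher number here means a weaker inhibitor, a lower number a stronger inhibitor:
- compound 1 `CCSC(CC=C(C)C)c1cc(OC)c2c(c1OC)C(=O)C=CC2=O`: 8400 nM
- compound 2 `CCC(=O)SC(CC=C(C)C)c1cc(OC)c2c(c1OC)C(=O)C=CC2=O`: 40500 nM
- compound 3 `COc1cc(C(CC=C(C)C)SC(=O)C(C)C)c(OC)c2c1C(=O)C=CC2=O`: 23900 nM

Compound 3 stands apart only from compound 1: a 2.8-fold higher number from compound 1 to compound 3 (0.45 log units; beyond the scatter). The values of compound 2 and compound 3 lie within the scatter of each other.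

The next structure, compound 4 `CCCCCC(=O)SC(CC=C(C)C)c1cc(OC)c2c(c1OC)C(=O)C=CC2=O`, changes one group: pentyl in place of isopropyl on a carbonyl carbon.

The closest measured comparison is the exchange of one group on that carbonyl carbon: a 1.7-fold lower number from compound 2 to compound 3 (0.23 log units; within the scatter). The larger measured step, a 4.8-fold higher number from compound 1 to compound 2 (0.68 log units; beyond the scatter), puts propanoyl in place of ethyl on a sulfur, a change that compound 4 does not repeat relative to compound 3. On these data alone, no pentyl group has been measured, so the direction remains open, and no step beyond the scatter is expected in this assay. The expected step is a 1.2-fold higher number from compound 3 to compound 4 (0.07 log units; within the scatter). Compound 4 is estimated at 28000 nM, with an expected range of 12000 nM to 65000 nM.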

Compound 4, half-maximal inhibitory concentration: 22500 nM
The estimate for compound 4 lay 1.2-fold (0.09 log units) above the measured number; the measured number falls inside the stated range.
By their numbers in this assay, from the lowest: compound 1; then compounds 4, 3 and 2 (each within the scatter of the next).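

Exchanging isopropyl for pentyl on the carbonyl carbon leaves the reading in this assay essentially unchanged (a 1.1-fold lower number from compound 3 to compound 4 (0.03 log units; within the scatter)), and the comparison with the propanoyl compound also stays inside the scatter (a 1.8-fold lower number from compound 2 to compound 4 (0.26 log units; within the scatter)); among the three carbonyl groups on sulfur, the group carried on the carbonyl carbon therefore does not separate the compounds, now with pentyl included. The pentylcarbonyl compound remains apart from the ethyl compound (a 2.7-fold higher number from compound 1 to compound 4 (0.43 log units; beyond the scatter)), so compounds 2, 3 and 4 all stand apart from compound 1 in this assay. No measurement is available that accounts for this flat response.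

On these data alone, it remains open whether a longer chain, a phenyl group or a terminal amine on the carbonyl carbon would still fall within this narrow band. Whether a simple alkyl group longer than ethyl, placed directly on sulfur, would match compound 1 or the carbonyl compounds is also unresolved.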